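Chloro for Methyl on the Aryl Amide of Compound 2

This account rests on a few compounds, and the source may have more. Where it says the series, first, only, none or still open, it means among the compounds named here.

Compound 2 `CCC(C=O)NC(=O)c1cccc(C(F)(F)F)c1C` and compound 1 `CC(NC(=O)c1cccc(C(F)(F)F)c1Cl)C(=O)C(N)=O` have both been tested in an assay on isolated protein for inhibition of cathepsin S (Homo sapiens), read by fluorescence; on this read-out lower numbers stand for stronger inhibition and higher numbers for weaker inhibition. In this assay compound 2 gives 18 nM. Compound 1 gives 30.9 nM in this assay. Compound 2 therefore has the lower of the two numbers shown, but its gap to compound 1 lies within the scatter, so no order between the two can be claimed; the two compounds also differ in more than one place, so their values are simply set side by side.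

Compound 3 `CCC(C=O)NC(=O)c1cccc(C(F)(F)F)c1Cl` has not yet been measured in this assay. It differs from compound 2 in a single place: chloro in place of methyl on an aromatic carbon, on an aromatic carbon of a six-membered aromatic ring of carbon only, ortho to a group of 8 heavy atoms and ortho to a trifluoromethyl group. For the measured compounds named here, no measured pair shows this change by itself, and nothing among the measured compounds points to a direction for it. For compound 3 a value of 15 nM is expected in this assay, within a range from 5 nM to 45 nM. The step that this estimate means, a 1.2-fold lower number from compound 2 to compound 3 (0.08 log units; within the scatter), is expected to stay within the scatter.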

Compound 3, half-maximal inhibitory concentration: 31 nM
Estimate against measurement, compound 3: 2.1-fold (0.32 log units) below, and the stated range covers the measured number.
By their numbers in this assay, from the lowest: compounds 2, 1 and 3 (each within the scatter of the next).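

The position ortho to a trifluoromethyl group now has its first reading of a single change: in this assay chloro in place of methyl on an aromatic carbon gives a 1.7-fold higher number from compound 2 to compound 3 (0.24 log units; within the scatter) and so stays within the scatter, which means that methyl and chloro cannot be told apart at this place. The second pair holds that chloro fixed and alters only the group on the amide-type nitrogen, where 1-formylpropyl in place of 1-(carbamoylcarbonyl)ethyl gives a 1.0-fold higher number from compound 1 to compound 3 (0.00 log units; within the scatter) and is likewise within the scatter, so these two groups cannot be told apart on this chloro-bearing core either. No supporting measurement bears on either step.

Both changes thus leave the number where it was, yet the compounds shown say nothing on whether a methoxy group, a nitrile, a bromine or a bare hydrogen at this place would give a step beyond the scatter. As far as these compounds go, it also remains open whether the same holds for the group on the amide-type nitrogen when it carries a longer chain, a ring or an amine, and whether 1-(carbamoylcarbonyl)ethyl would behave alike on the methyl-bearing core of compound 2.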